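The source may hold more compounds than are shown below. What is called first, only, known or untested is meant among the compounds shown, and "the series" means these compounds.

Measured compounds:
- compound 1, `Cc1ccc(-n2nc(C(=O)Nc3ccc(Oc4ncnc5ccsc45)cc3)c(C)cc2=O)cc1`, gives 11500 nM in a functional assay on A549 cells (Homo sapiens) for cytotoxicity, read by MTT assay, with a stated time of 72 h; on this read-out higher numbers stand for weaker inhibition and lower numbers for stronger inhibition
- compound 2, `Cc1cc(=O)n(-c2ccc(F)cc2)nc1C(=O)Nc1ccc(Oc2ncnc3ccsc23)cc1`, gives 2360 nM in this assay
- compound 3, `Cc1ccc(-n2nc(C(=O)Nc3ccc(Oc4ncnc5sccc45)c(F)c3)c(C)cc2=O)cc1`, gives > 40000 nM in this assay, which is a limit of the assay and not a number

The three measured compounds fall into two cores. Compound 1 and compound 2 share one core and differ only by fluoro in place of methyl on an aromatic carbon; this change gave a 4.9-fold lower number from compound 1 to compound 2 (0.69 log units; beyond the scatter). Compound 3 carries the other core; how it differs from compound 1 is not broken down here. For compound 3 the value stands at the limit of > 40000 nM in this assay, at which 1 of the 3 values shown sits, so only a limit is known for it.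

Compound 4, `Cc1cc(=O)n(-c2ccc(F)cc2)nc1C(=O)Nc1ccc(Oc2ncnc3sccc23)c(F)c1`, has not yet been measured in this assay. It differs from compound 3 by fluoro in place of methyl on an aromatic carbon, the same change that separates compound 2 from compound 1, and the place of the change reads the same in both pairs.

Because the step of a 4.9-fold lower number from compound 1 to compound 2 (0.69 log units; beyond the scatter) lies beyond the scatter, a step of a similar size from compound 3 to compound 4, an at least 2.0-fold lower number from compound 3 to compound 4 (0.30 log units; that floor lies within the scatter), is expected. Yet since compound 3 rests on a limit rather than a number, the starting point is uncertain, and the expected value for compound 4 can only be loosely placed. Compound 4 is therefore estimated at 20000 nM, with a range from 6000 nM to 60000 nM, and it remains quite possible that the assay again reports only a limit for compound 4.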

Compound 4, half-maximal inhibitory concentration: 2620 nM
The estimate for compound 4 lay 7.6-fold (0.88 log units) above the measured number; measured number below the stated range.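

In this assay, the change from 4-methylphenyl to 4-fluorophenyl moved the number the same way on both cores, giving a 4.9-fold lower number from compound 1 to compound 2 (0.69 log units; beyond the scatter) on the first and an at least 15-fold lower number from compound 3 to compound 4 (1.18 log units; beyond the scatter) on the second, so within these two pairs the direction carried over from one core to the other. The size did not carry over, and the core of compound 3 responded more strongly to the same change than the core of compound 1 did: the same change on two cores in this assay, a 4.9-fold lower number (0.69 log units; beyond the scatter) from compound 1 to compound 2 and an at least 15-fold lower number (1.18 log units; beyond the scatter) from compound 3 to compound 4, at least 3.1-fold (0.49 log units) apart, beyond the scatter of two such steps. Within the data shown here, this rests on only two pairs and sets no rule for the series, and it does not show how large the step on the second core truly is, because compound 3 has only a limit, so the step is a floor and its real size stays unknown: the limit of > 40000 nM in this assay, at which 1 of the 4 values shown sits.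

The compounds shown leave open whether the same pattern would appear with another group in that place on the outer phenyl ring, such as chloro, methoxy, trifluoromethyl or an amine, or with no group there at all. Among these compounds, they also do not tell which feature of the core of compound 3 sets its step apart from that of compound 1, since no compound separates the ways in which the two cores differ.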